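A few compounds are considered here, and "the series" means these few. Any claim that something is new, unique, unknown or untested is made for them only; others in the source may bear on it.

Compound 3 `Cc1cc(C)c(Oc2cc(Nc3ccc(C#N)cc3)ncc2C(=O)NCc2cn(Cc3cccc(C#N)c3)nn2)c(C)c1` shares its core with compound 1 `Cc1ccc(Cn2cc(CNC(=O)c3cnc(Nc4ccc(C#N)cc4)cc3Oc3c(C)cc(C)cc3C)nn2)cc1` and compound 2 `Cc1cccc(Cn2cc(CNC(=O)c3cnc(Nc4ccc(C#N)cc4)cc3Oc3c(C)cc(C)cc3C)nn2)c1`, the three differing only in the group on a saturated chain carbon bound to an aromatic nitrogen. In an ADME assay on MT4 cells (Homo sapiens) for cytotoxicity, read by MTT assay, with a stated time of 5 days (a higher number here means that more compound is tolerated, a lower number that less compound is tolerated), compound 1 gives 165000 nM. Compound 2 gives 114000 nM. For compound 3 this assay reports only a limit, >= 129000 nM, so where compound 3 stands among the numbers is open upward; this is the limit of >= 129000 nM in this assay, at which 1 of the 3 values shown sits.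

Compound 4 `CCOC(=O)CCn1cc(CNC(=O)c2cnc(Nc3ccc(C#N)cc3)cc2Oc2c(C)cc(C)cc2C)nn1` carries the change ((ethoxycarbonyl)methyl in place of 3-cyanophenyl on a saturated chain carbon bound to an aromatic nitrogen). Among the measured compounds shown here, two measured steps touch the same place: a 1.4-fold lower number from compound 1 to compound 2 (0.16 log units; within the scatter) and a step that the limit leaves unreadable from compound 1 to compound 3. The remaining step, an at least 1.1-fold higher number from compound 2 to compound 3 (0.05 log units; that floor lies within the scatter), is also small. None of these shows movement beyond the scatter, so no step beyond the scatter is expected here either. Compound 4 is therefore expected to sit near 140000 nM, with a range from 60000 nM to 350000 nM. That estimate means a step that the limit leaves unreadable from compound 3 to compound 4, expected to stay within the scatter, with a fair chance that this assay again returns only a limit.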

Compound 4, half-maximal cytotoxic concentration: 21500 nM
Beside the measured number, compound 4's estimate is 6.5-fold (0.81 log units) above it; the measured number lies below the stated range.
By their numbers in this assay, from the lowest: compound 4; then compounds 2 and 1 (each within the scatter of the next).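

In this assay, this place on a saturated chain carbon bound to an aromatic nitrogen proves able to move the number beyond the scatter, which the groups bearing a six-membered aromatic ring had not shown: with (ethoxycarbonyl)methyl in their stead the record reads a 7.7-fold lower number from compound 1 to compound 4 (0.89 log units; beyond the scatter), a 5.3-fold lower number from compound 2 to compound 4 (0.72 log units; beyond the scatter) and an at least 6.0-fold lower number from compound 3 to compound 4 (0.77 log units; beyond the scatter). The last of these steps is only a floor, for the entry of compound 3 is a limit and not a number: the limit of >= 129000 nM in this assay, at which 1 of the 4 values shown sits. With its steps to all the others beyond the scatter, compound 4 is the least tolerated of the compounds shown, and it alone carries no ring at this place.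

From the compounds shown here alone, whether the step follows the loss of the aromatic ring or the ethoxycarbonyl group itself stays open. So does whether a carboxylic acid, an amine or a plain longer alkyl chain at this place would stand with compound 4 or with the aromatic groups.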